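The source may hold more compounds than are shown below. What is called first, only, known or untested is meant among the compounds shown, and "the series" means these compounds.

Measured in a functional assay on MGC-803 cells (Homo sapiens) for inhibition, read by MTT assay, with a stated time of 72 h; on this read-out lower numbers stand for stronger inhibition and higher numbers for weaker inhibition:
compound 1 `Cc1cc(Nc2cc(-c3ccccc3)[nH]n2)n2nc(SCc3c(Cl)cccc3Cl)nc2n1` — 5280 nM
compound 2 `Cc1cc(Nc2cc(-c3ccccc3)[nH]n2)n2nc(SCc3ccc(F)cc3)nc2n1` — 3270 nM
compound 3 `CCCSc1nc2nc(C)cc(Nc3cc(-c4ccccc4)[nH]n3)n2n1` — 12600 nM

Compound 3 stands highest of the three numbers in this assay, beyond the scatter of both others. Compound 4 `Cc1cc(Nc2cc(-c3ccccc3)[nH]n2)n2nc(SCC3CC3)nc2n1` is not yet measured and differs from compound 3 in one place: cyclopropyl in place of ethyl on a saturated chain carbon bound to a sulfur. Among the measured compounds shown here, the steps that bear on this change are a 2.4-fold higher number from compound 1 to compound 3 (0.38 log units; beyond the scatter) and a 3.9-fold higher number from compound 2 to compound 3 (0.59 log units; beyond the scatter); read backwards, each swap of ethyl for a ring-bearing group on that carbon gave a modestly lower number. Cyclopropyl adds one ring of three carbon atoms where ethyl has two, a smaller change than either swap, so a downward step of lesser size is expected, possibly within the scatter. Compound 4 is therefore expected near 7500 nM, range 3500 nM to 16000 nM. The expected step is a 1.7-fold lower number from compound 3 to compound 4 (0.23 log units; within the scatter).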

Compound 4, half-maximal inhibitory concentration: 16100 nM
Compound 4: middle estimate off by 2.1-fold (0.33 log units), on the low side; measured number outside the range, above it.
By their numbers in this assay, from the lowest: compounds 2 and 1 (each within the scatter of the next); then compounds 3 and 4 (each within the scatter of the next).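

In this assay a small saturated ring on the saturated chain carbon bound to a sulfur does not reproduce the lower numbers of the phenyl-bearing compounds: a 1.3-fold higher number from compound 3 to compound 4 (0.11 log units; within the scatter) stays level with the ethyl case. The gaps of a 4.9-fold higher number from compound 2 to compound 4 (0.69 log units; beyond the scatter) and a 3.0-fold higher number from compound 1 to compound 4 (0.48 log units; beyond the scatter) remain, so among these four compounds a ring as such does not go with the lower numbers, only the 4-fluorophenyl and 2,6-dichlorophenyl groups do. No supporting data offer an explanation for this.
Open, as far as these compounds go, is where an unsubstituted phenyl or a longer chain such as hexyl on that carbon would fall.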